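Quaternary ammonium chain in place of carboxymethyl ether

This account rests on a few compounds, and the source may have more. Where it says the series, first, only, none or still open, it means among the compounds named here.

Three compounds of this series carry a measurement in a functional assay for inhibition, with Rattus norvegicus as the target, using microsomes; a higher number here means a weaker inhibitor, a lower number a stronger inhibitor. Compound 1 `O=c1cc(-c2ccc(O)c(O)c2)oc2cc(O)ccc12` gives 11000 nM, compound 2 `COc1ccc2c(=O)cc(-c3ccc(O)c(O)c3)oc2c1` gives 2500 nM, and compound 3 `O=C(O)COc1c(-c2ccc(O)c(O)c2)oc2ccccc2c1=O` gives 6500 nM. Compound 3 stands second highest of the three numbers: its gap to compound 1 lies within the scatter, while compound 2 sits beyond the scatter with a lower number than compound 3. Going by the values given here, the only single-site step among the measured compounds is a 4.4-fold lower number from compound 1 to compound 2 (0.64 log units; beyond the scatter), methyl in place of hydrogen on an oxygen on an aromatic ring.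

Compound 4 `C[N+](C)(C)CCCOc1c(-c2ccc(O)c(O)c2)oc2ccccc2c1=O` differs from compound 3 by a group of 6 heavy atoms (5 carbon, 1 nitrogen; no ring) in place of a group of 3 heavy atoms (1 carbon, 2 oxygen; no ring), on a saturated chain carbon bound to an oxygen on an aromatic ring. Among the compounds with values here, no measured step covers a change of this kind: the step from compound 1 to compound 2 sits on a different oxygen and swaps a hydrogen for a methyl, not a carboxy for a charged chain group, so it gives no direct guidance. With nothing to lean on, the expected outcome in this assay is no step beyond the scatter, the estimated step being no change at the digits printed from compound 3 to compound 4 (within the scatter) with a wide range to either side. Compound 4 is therefore expected to give about 6500 nM, between 2000 nM and 20000 nM.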

Compound 4, half-maximal inhibitory concentration: 1200 nM
For compound 4 the middle estimate is 5.4-fold (0.73 log units) above the measured one; measured number outside the range, below it.
By their numbers in this assay, from the lowest: compound 4; then compound 2; then compounds 3 and 1 (each within the scatter of the next).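

In this assay the ether chain on this oxygen is not a silent place in the series: the step reads a 5.4-fold lower number from compound 3 to compound 4 (0.73 log units; beyond the scatter) as the carboxy leaves and a group of 6 heavy atoms with net charge +1 enters. Going by these compounds alone, the only earlier single-site step, a 4.4-fold lower number from compound 1 to compound 2 (0.64 log units; beyond the scatter), lay on a different oxygen, so this is the first reading at this position, and it shows that a quaternary ammonium chain is accepted here and gives a lower number than the carboxymethyl ether. No measurement at hand speaks to the reason for this step.

The change alters net charge, hydrogen-bond donors and acceptors and heavy-atom count all at once, and the compounds shown do not separate these. From the compounds shown here alone, a tertiary amine on the same chain, a carboxylic acid on a longer chain or a shorter chain ending in trimethylammonium would pull them apart, and whether a methyl ether on the other oxygen, as in compound 2, adds to this change also stays open.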